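The compounds below may be only part of what the source reports. "The series", "measured", "known", "first", "only" and "open" are said of these compounds alone.

Measured in a functional assay on HepG2 cells (Homo sapiens) for inhibition, read by MTT assay; a higher number here means a weaker inhibitor of growth, a lower number a stronger inhibitor of growth:
- compound 1 `COc1cc2oc(-c3cccc(NC(=O)c4ccc(Br)cc4)c3)cc(=O)c2c(OC)c1OC`: 8850 nM
- compound 2 `COc1cc2oc(-c3cccc(NC(=O)c4cccc(Br)c4)c3)cc(=O)c2c(OC)c1OC`: 10900 nM
- compound 3 `COc1cc2oc(-c3cccc(NC(=O)c4ccc(C)cc4)c3)cc(=O)c2c(OC)c1OC`: 9750 nM

Compound 3 is not separated from either of the other two compounds: the readings are a 1.1-fold higher number from compound 1 to compound 3 (0.04 log units; within the scatter) and a 1.1-fold lower number from compound 2 to compound 3 (0.05 log units; within the scatter). Both steps lie within the scatter, so the three values form one group.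

Next is compound 4 `COc1ccccc1C(=O)Nc1cccc(-c2cc(=O)c3c(OC)c(OC)c(OC)cc3o2)c1`, which differs from compound 3 as follows: 2-methoxyphenyl in place of 4-methylphenyl on a carbonyl carbon. All three measured steps change the same aryl group on the carbonyl carbon. Besides the two above, the third is a 1.2-fold higher number from compound 1 to compound 2 (0.09 log units; within the scatter). None of them was large enough to leave the scatter, so no step beyond the scatter is expected here. The evidence is limited, however, since no measured compound carries a 2-methoxyphenyl group, and the range is kept wide for that reason.

The estimated step is a 1.0-fold higher number from compound 3 to compound 4 (0.01 log units; within the scatter).

For compound 4 the expected value is 10000 nM, with an estimated range of 5000 nM to 20000 nM.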

Compound 4, concentration for 50% growth inhibition: 7530 nM
The estimate for compound 4 lay 1.3-fold (0.12 log units) above the measured number; the measured number falls inside the stated range.
By their numbers in this assay, from the lowest: compounds 4, 1, 3 and 2 (each within the scatter of the next).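

In this assay, going by these compounds alone, the 2-methoxyphenyl group on the carbonyl carbon, the first aryl group in this set with an oxygen and a hydrogen-bond acceptor, stays within the scatter of all three earlier groups (a 1.3-fold lower number from compound 3 to compound 4 (0.11 log units; within the scatter); a 1.4-fold lower number from compound 2 to compound 4 (0.16 log units; within the scatter); a 1.2-fold lower number from compound 1 to compound 4 (0.07 log units; within the scatter)). The flat reading at this position now covers 4-bromophenyl, 3-bromophenyl, 4-methylphenyl and 2-methoxyphenyl, and no exception appears among these four compounds. No available measurement bears on why the four values stay together.

From the compounds shown here alone, whether any group on the carbonyl carbon can move the number beyond the scatter remains open, for example a phenyl ring carrying an amine or a carboxylic acid. Also open, going by these compounds, is how changes to the amide hydrogen or the shared core would read, as all four compounds keep both unchanged.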